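The compounds below may be only part of what the source reports. "The series", "measured", "known", "first", "only" and "open" are said of these compounds alone.

Compound 1 `C[C@H]1[C@H](NCc2ccsc2)C[C@H]2C[C@@H]1C2(C)C`: 50000 nM
Compound 2 `C[C@H]1[C@H](NCc2cc(-c3ccccc3)cs2)C[C@H]2C[C@@H]1C2(C)C`: 5000 nM

In an ADME assay on MDCK cells (Canis lupus familiaris) for cytotoxicity, read by microscopy, with a stated time of 48 h (on this read-out higher numbers stand for lower toxicity in this test and lower numbers for higher toxicity in this test), compound 1 stands at the higher of the two numbers, with compound 2 at 5000 nM, a gap beyond the usual scatter. Compound 3 `Cc1csc(CN[C@@H]2C[C@H]3C[C@@H]([C@H]2C)C3(C)C)n1` has not yet been tested in this assay. It differs from compound 1 by 4-methyl-1,3-thiazol-2-yl in place of thiophen-3-yl on a saturated chain carbon bound to an amine nitrogen. Among the compounds with values here, no measured pair shows this change, so the expectation for compound 3 rests on compound 1 alone, whose value is 50000 nM. Compound 3 is expected to stay close to it, with a step of a 1.3-fold lower number from compound 1 to compound 3 (0.10 log units; within the scatter) that is unlikely to exceed the scatter. The estimate for compound 3 is 40000 nM, between 12000 nM and 100000 nM.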

Compound 3, minimum cytotoxic concentration: > 100000 nM
Compound 3: only a limit was reported; the forecaster's own chance of this, stated with the estimate: 15%; middle value at least 2.5-fold (0.39 log units) away from the limit.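

In this assay compound 3 gives only a limit, > 100000 nM. Putting 4-methyl-1,3-thiazol-2-yl in place of thiophen-3-yl on a saturated chain carbon bound to an amine nitrogen gives an at least 2.0-fold higher number from compound 1 to compound 3 (0.30 log units; that floor lies within the scatter), the first step read at this place. Only the floor of that step can be read, so its full size stays unknown: the limit of > 100000 nM in this assay, at which 1 of the 3 values shown sits.

The ring nitrogen and the methyl enter together, and the compounds shown do not separate them. As far as these compounds go, how a pyridin-2-yl ring or a carboxylic acid would read at this place also stays open.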